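The source may hold more compounds than are shown below. What is called first, only, known or untested is meant among the compounds shown, and "the series" means these compounds.

Measured compounds in a functional assay on Raji cells (Homo sapiens) for antiproliferative activity, read by MTT assay, with a stated time of 72 h; on this read-out lower numbers stand for stronger inhibition and higher numbers for weaker inhibition:
Compound 1 `Cc1ccc(CN2CCC(c3noc(CN(C)c4ncc(/C=C/C(=O)NO)cn4)n3)CC2)cc1`: 293 nM
Compound 2 `CN(Cc1nc(C2CCN(Cc3ccccc3)CC2)no1)c1ncc(C(=O)NO)cn1`: 27.6 nM
Compound 3 `CN(Cc1nc(C2CCN(Cc3ccccc3F)CC2)no1)c1ncc(C(=O)NO)cn1`: 98.6 nM

Of these three, compound 2 has the lowest number at 27.6 nM, and its steps to both others lie beyond the scatter. The next compound to be tested, compound 4 `CN(Cc1nc(C2CCN(Cc3ccc(F)cc3)CC2)no1)c1ncc(C(=O)NO)cn1`, matches compound 2 except that benzyl becomes 4-fluorobenzyl: fluoro in place of hydrogen on an aromatic carbon. Among the measured compounds shown here, one measured step bears on this change: a 3.6-fold higher number from compound 2 to compound 3 (0.55 log units; beyond the scatter). It is the same kind of replacement, fluoro in place of hydrogen on an aromatic carbon, and it is modest. It is also a single case, and compound 3 carries its fluoro at a different place on the ring from compound 4, so it offers only a loose guide. A step in the same direction but somewhat smaller therefore seems likely in this assay. The expected change is a 2.0-fold higher number from compound 2 to compound 4 (0.30 log units; within the scatter). For compound 4 the estimated value is 55 nM, with an expected range from 20 nM to 150 nM.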

Compound 4, half-maximal inhibitory concentration: 22 nM
Estimate against measurement, compound 4: 2.5-fold (0.40 log units) above, within the range that was stated.
By their numbers in this assay, from the lowest: compounds 4 and 2 (each within the scatter of the next); then compound 3; then compound 1.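

In this assay, fluoro placed para to a large group gives a step within the scatter, a 1.3-fold lower number from compound 2 to compound 4 (0.10 log units; within the scatter), so the earlier step of a 3.6-fold higher number from compound 2 to compound 3 (0.55 log units; beyond the scatter) does not apply to every fluoro in place of hydrogen on this aromatic ring. The place of the fluoro makes a difference here: 4-fluorophenyl in place of 2-fluorophenyl gives a 4.5-fold lower number from compound 3 to compound 4 (0.65 log units; beyond the scatter), a step beyond the scatter. Nothing measured here explains this difference between the two fluoro compounds.

The compounds shown leave open whether chloro, methoxy or trifluoromethyl in the same place, para to a large group, would also stay within the scatter of compound 2. They also leave open how a pyridyl ring would compare with the phenyl ring of the benzyl group.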